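The compounds below may be only part of what the source reports. "The series", "measured", "known", "first", "only" and "open" are said of these compounds alone.

Two compounds of the series have numbers in a functional assay on SiHa cells (Homo sapiens) for cytotoxicity, read by MTT assay, with a stated time of 48 h; on this read-out higher numbers stand for weaker inhibition and lower numbers for stronger inhibition. Compound 1 `CCCCCCCCCCCCCCNC(=O)[C@@H](NC(=O)/C=C/c1ccccc1)[C@@H](C)O` gives 35800 nM. Compound 2 `CCCCCCCCCCCCCCNC(=O)[C@@H](NS(=O)(=O)c1ccc(C)cc1)[C@@H](C)O` gives 19200 nM. Among the compounds with values here, the only measured step, a 1.9-fold lower number from compound 1 to compound 2 (0.27 log units; within the scatter), exchanges the group on the amine nitrogen, and compound 2 stands together with compound 1 inside the scatter rather than apart from it.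

Compound 3 `CCCCCCCCCCCCCCNC(=O)[C@@H](NS(=O)(=O)c1cccs1)[C@@H](C)O` keeps the sulfonamide of compound 2 and changes only the ring on the sulfonyl sulfur: thiophen-2-yl in place of 4-methylphenyl on a sulfonyl sulfur. Within the data shown here, no measured step exchanges one ring for another on that sulfur. The step from compound 1 to compound 2 touches the same part of the molecule but is a different change, and it stayed within the scatter, so it gives no direction for this one. Compound 3 is therefore expected to show a step of a 1.0-fold higher number from compound 2 to compound 3 (0.02 log units; within the scatter), with no change beyond the scatter. The estimate for compound 3 in this assay is 20000 nM, expected to lie between 8000 nM and 50000 nM.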

Compound 3, half-maximal inhibitory concentration: 20400 nM
The estimate for compound 3 lay 1.0-fold (0.01 log units) below the measured number, and the stated range covers the measured number.
By their numbers in this assay, from the lowest: compounds 2, 3 and 1 (each within the scatter of the next).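

In this assay, the ring on the sulfonyl sulfur can now be read on its own: thiophen-2-yl in place of 4-methylphenyl gives a 1.1-fold higher number from compound 2 to compound 3 (0.03 log units; within the scatter), so this exchange of a six-membered ring for a five-membered ring with one hetero atom leaves the number within the scatter. The second sulfonyl group likewise does not separate from the (2-phenylethenyl)carbonyl group on the amine nitrogen, with a 1.8-fold lower number from compound 1 to compound 3 (0.24 log units; within the scatter). No evidence is available that bears on this result.

Still open, going by these compounds, is whether a ring carrying an amine or a carboxylic acid on the sulfonyl sulfur would give a step beyond the scatter. Also open, on these data alone, is whether a shorter chain in place of the long chain shared by compound 1, compound 2 and compound 3 would do so.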